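The source may hold more compounds than are shown below. What is called first, only, known or untested is meant among the compounds shown, and "the series" means these compounds.

Working notes on the series.

Two members have been run in a functional assay on M14 cells (Homo sapiens) for cytotoxicity, read by sulforhodamine B assay, with a stated time of 48 h; on this read-out higher numbers stand for weaker inhibition of growth and lower numbers for stronger inhibition of growth. Compound 1 `ClCc1ccc(Cn2cnc3c(Cl)ncnc32)cc1` carries a chloromethyl group on the benzyl ring and a single chloro on the fused core; in this assay compound 1 gives 3460 nM. Compound 2 `ClCc1cccc(Cn2cnc3ncnc(Cl)c32)c1` differs in the placement of the chloromethyl group on the benzyl ring and in the way the core is attached; in this assay compound 2 gives 14500 nM. Compound 2 thus stands at the highest of the two numbers recorded so far, and the number for compound 1 is lower by a margin beyond the usual scatter. Among the compounds with values here, no pair of measured compounds differs in one place only, so no single step has been quantified.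

The next member, compound 3 `ClCc1cccc(Cn2cnc3nc(Cl)nc(Cl)c32)c1`, follows from compound 2 by one change: chloro in place of hydrogen on an aromatic carbon. Nothing measured bears directly on this change. The step from compound 2 to compound 3 is expected to be small, likely toward a somewhat lower number, a 1.6-fold lower number from compound 2 to compound 3 (0.21 log units; within the scatter). For compound 3 the estimated value in this assay is 9000 nM, with a range from 3000 nM to 27000 nM.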

Compound 3, concentration for total growth inhibition: 2630 nM
The estimate for compound 3 lay 3.4-fold (0.53 log units) above the measured number, and the stated range ends above it.
By their numbers in this assay, from the lowest: compounds 3 and 1 (each within the scatter of the next); then compound 2.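

In this assay chloro in place of hydrogen on an aromatic carbon goes with a 5.5-fold lower number from compound 2 to compound 3 (0.74 log units; beyond the scatter) and gives the series its first quantified single change. The position, on an aromatic carbon of a six-membered aromatic ring with 2 nitrogen and between two ring nitrogen atoms, therefore accepts a chloro group, and in this single pair the number moves toward stronger inhibition of growth while the rest of the structure stays the same. Nothing on hand accounts for the size or direction of this step, so it stands as an observation only.

One pair cannot show whether this step is particular to chloro, and an amine, a methoxy group or a fluoro group at the same position would be needed to separate the effect of that group from the effect of any replacement of hydrogen. As far as these compounds go, it also remains open whether the same change gives a step of similar size when the chloromethyl group stands elsewhere on the benzyl ring, or when a longer chain takes its place.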